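Furan-substituted ribonucleosides: fibroblast toxicity limits

A few compounds are considered here, and "the series" means these few. Any claim that something is new, unique, unknown or untested is made for them only; others in the source may bear on it.

Measured compounds:
compound 1 `COc1nc(N)nc2c1c(-c1ccoc1)cn2[C@@H]1O[C@H](CO)[C@@H](O)[C@H]1O` — limit only, > 100000 nM
compound 2 `Cc1nc(N)c2c(-c3ccoc3)cn([C@@H]3O[C@H](CO)[C@@H](O)[C@H]3O)c2n1` — limit only, > 100000 nM

In an ADME assay on MRC5 cells (Homo sapiens), read by MTT assay, with a stated time of 72 h (a higher number here means a weaker inhibitor, a lower number a stronger inhibitor), compound 1 is reported only as a limit, > 100000 nM. Compound 2 likewise gives only a limit in this assay, > 100000 nM. Both results rest at the limit of > 100000 nM in this assay, at which 2 of the 2 values shown sit, so the two compounds cannot be placed in any order against each other, and compound 2 stands simply at the limit with no number of its own.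

Compound 3 `Nc1nc(N)c2c(-c3ccoc3)cn([C@@H]3O[C@H](CO)[C@@H](O)[C@H]3O)c2n1` is the next compound in the series. It differs from compound 2 by amino in place of methyl on an aromatic carbon. Within the data shown here, no step between two measured compounds is available to calibrate a change of this kind, and both measured values are limits rather than numbers.

In this assay the step from compound 2 to compound 3 is expected to be none beyond the scatter, with the outcome most likely again a limit. Compound 3 is expected to give about 100000 nM in this assay, within 30000 nM to 300000 nM. The step this estimate implies is a number no higher from compound 2 to compound 3 (the limit leaves the size open).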

Compound 3, half-maximal inhibitory concentration: > 100000 nM
Compound 3: only a limit was reported; the forecaster's own chance of this, stated with the estimate: 85%; the middle value lies on the limit itself.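

In this assay compound 3 gives > 100000 nM, again a limit and not a number, so no step can be read from compound 1 or compound 2 to compound 3: the limit of > 100000 nM in this assay, at which 3 of the 3 values shown sit.

The compounds shown leave open how the three rank in this assay, and whether amino, methyl or methoxy on that aromatic carbon makes any difference there.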